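The compounds below may be only part of what the source reports. "The series", "measured", "known", "first", "only" and "open" are said of these compounds alone.

Measured in a functional assay on CNE-2 cells (Homo sapiens) for antiproliferative activity, read by sulforhodamine B assay, with a stated time of 48 h; on this read-out higher numbers stand for weaker inhibition and lower numbers for stronger inhibition:
- compound 1 `COc1ccc(/C=C/C(=O)c2ccccc2-c2ccc(F)cc2)cc1OC`: 81 nM
- compound 2 `COc1cc(/C=C/C(=O)c2ccccc2-c2ccc(F)cc2)ccc1O`: 2500 nM

Of these two, compound 1 has the lower number and so is the stronger inhibitor. Compound 3 `COc1ccc(/C=C/C(=O)c2ccccc2-c2ccc(F)cc2)cc1B(O)O` has not been measured yet. It keeps the core of compound 1 but loses a methoxy group: a group of 3 heavy atoms (1 boron, 2 oxygen; no ring) in place of a group of 2 heavy atoms (1 carbon, 1 oxygen; no ring), on an aromatic carbon. The new group sits on an aromatic carbon, ortho to a methoxy group that remains.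

Among the compounds with values here, only one measured step bears on this change, and only loosely. It is a 31-fold higher number from compound 1 to compound 2 (1.49 log units; beyond the scatter), a large step in which hydrogen replaces methyl on an oxygen on an aromatic ring. That step alters a different methoxy group and removes no oxygen, so it gives a hint about direction rather than a direct precedent. Within the data shown here, no measured compound carries the boron-containing group, which leaves the size of the change poorly defined. In this assay, a weaker result is expected, probably by less than the full size of that one step, and the expected change is a 4.9-fold higher number from compound 1 to compound 3 (0.69 log units; beyond the scatter). For compound 3 the estimated value is 400 nM, with an expected range from 60 nM to 3000 nM.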

Compound 3, half-maximal inhibitory concentration: 21 nM
For compound 3 the middle estimate is 19-fold (1.28 log units) above the measured one; the measured number lies below the stated range.
By their numbers in this assay, from the lowest: compound 3; then compound 1; then compound 2.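

In this assay, replacing this methoxy group, which is ortho to the methoxy group that remains and meta to a large group, with the boron-containing group gives a 3.9-fold lower number from compound 1 to compound 3 (0.59 log units; beyond the scatter), a modest gain in inhibition that lies beyond the usual scatter. The methoxy group at this position is therefore not needed for strong inhibition, and a group with hydrogen-bond donors, which the methoxy group lacks, is accepted here. Within the data shown here, the only earlier step, a 31-fold higher number from compound 1 to compound 2 (1.49 log units; beyond the scatter), changed a different methoxy group and went the opposite way, so the two methoxy groups of compound 1 do not respond alike to these two changes, and nothing available explains the gain at this position.

The compounds shown leave open whether boron itself matters or whether another group with hydrogen-bond donors, such as an amine or a carboxylic acid, would do as well at this position. Among these compounds, they also leave open how the boron-containing group would behave in place of the other methoxy group, the one altered in compound 2.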